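A few compounds are considered here, and "the series" means these few. Any claim that something is new, unique, unknown or untested is made for them only; others in the source may bear on it.

Of the compounds shown here, three built on a shared core have so far been tested in an ADME assay on HEL cells (Homo sapiens) for cytotoxicity, with a stated time of 3 days; a lower number here means that less compound is tolerated, a higher number that more compound is tolerated. Compound 1 `CCCCCc1ccc(CCc2cc3cn([C@H]4C[C@H](O)[C@@H](CO)O4)c(=O)nc3o2)cc1` gives > 470000 nM, which is a limit of the assay and not a number. Compound 2 `CCCCCCCCCCc1cc2cn([C@H]3C[C@H](O)[C@@H](CO)O3)c(=O)nc2o1` gives > 510000 nM, which is also a limit of the assay. Within the data shown here, compound 3 `Cc1ccc(C#Cc2cc3cn([C@H]4C[C@H](O)[C@@H](CO)O4)c(=O)nc3o2)cc1` gives 510000 nM, and this is the only actual number among the three results, so it has no measured neighbour to be ranked against.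

Compound 4 `Cc1ccc(CCc2cc3cn([C@H]4C[C@H](O)[C@@H](CO)O4)c(=O)nc3o2)cc1` is the next to be measured, and it differs from compound 3 in a single group: 2-(4-methylphenyl)ethyl in place of 2-(4-methylphenyl)ethynyl on an aromatic carbon. In words, this places 2-(4-methylphenyl)ethyl in place of 2-(4-methylphenyl)ethynyl on an aromatic carbon. The group keeps its ring and its methyl, and only the link to the core changes, losing its triple bond.

Among the measured compounds shown here, no pair of measured compounds differs in just one place, so there is no direct precedent for the size of this change. For the measured compounds named here, with compound 3 at 510000 nM as the only number to go on, no step beyond the usual scatter, in either direction, is expected in this assay. The expected change is a 1.1-fold lower number from compound 3 to compound 4 (0.03 log units; within the scatter), an estimate that stays within that scatter. For compound 4 the estimated value is 480000 nM, with an expected range from 220000 nM to 900000 nM.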

Compound 4, half-maximal cytotoxic concentration: > 540000 nM
Compound 4: a limit, no number (the forecaster's own chance of this, stated with the estimate: 70%); middle value at least 1.1-fold (0.05 log units) away from the limit.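

In this assay, 2-(4-methylphenyl)ethyl in place of 2-(4-methylphenyl)ethynyl, on an aromatic carbon next to the ring oxygen, gives an at least 1.0-fold higher number from compound 3 to compound 4 (0.02 log units; that floor lies within the scatter). Compound 4 has a limit of the assay and not a number: the limit of > 540000 nM in this assay, at which 1 of the 4 values shown sits. Among these compounds, this is the first single-place comparison with a readable floor, and it shows that swapping the triple-bonded link for the saturated one gives no sign of a lower tolerated concentration, although the true size of the step remains unknown, and the steps to compound 4 from compound 1 and from compound 2 join two limits and cannot be read.

Since three of the four results are limits, these compounds cannot rank the side groups at this position against one another, and they do not show what it would take to bring the tolerated concentration clearly down. An amine or a carboxylic acid in place of the methyl on the aromatic ring of the 2-(4-methylphenyl)ethyl group remains untested among the compounds shown, so whether such a change would move the result in this assay is open.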